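The source may hold more compounds than are shown below. What is called first, only, known or untested is meant among the compounds shown, and "the series" means these compounds.

Compound 2 `O=S(=O)(c1cccc(Cl)c1)c1cn(C2CCNC2)c2ccccc12` gives, in an assay on HeLa cells for displacement of a labelled ligand from 5-hydroxytryptamine receptor 6 (Homo sapiens), with a stated time of 2 h (on this read-out higher numbers stand for weaker inhibition and lower numbers for stronger inhibition), a value of 3.2 nM. Within the data shown here, of the two numbers recorded so far this is the lower one; its only neighbour, compound 1 `O=S(=O)(c1cccc(F)c1)c1cn(C2CCNC2)c2ccccc12`, gives 4.7 nM in this assay, and the step of a 1.5-fold lower number from compound 1 to compound 2 (0.17 log units; within the scatter) stays within the usual scatter, so the two compounds cannot be ordered on these data.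

Compound 3 `COc1ccc2c(S(=O)(=O)c3cccc(Cl)c3)cn(C3CCNC3)c2c1` differs from compound 2 by a single change, (methoxy in place of hydrogen on an aromatic carbon). Among the measured compounds shown here, no measured step touches this part of the shared core: the one step recorded, from compound 1 to compound 2, concerns the halogen on the other aromatic ring and was small. There is therefore no measured basis for predicting a shift beyond the scatter, and the expected step of a 1.1-fold lower number from compound 2 to compound 3 (0.03 log units; within the scatter) is put at about nothing. For compound 3 the expected value in this assay is 3 nM, with a range from 1 nM to 10 nM.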

Compound 3, inhibition constant: 4.6 nM
Estimate against measurement, compound 3: 1.5-fold (0.19 log units) below; low and high end bracket the measured number.
By their numbers in this assay, from the lowest: compounds 2, 3 and 1 (each within the scatter of the next).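

Among these compounds, until now the only measured step concerned the halogen on the other aromatic ring, and it said nothing about the six-membered aromatic ring of carbon only in the fused system. The step of a 1.4-fold higher number from compound 2 to compound 3 (0.16 log units; within the scatter) in this assay shows that methoxy in place of hydrogen on this carbon leaves the two compounds impossible to order, so this position carries the group without a shift that can be told from the scatter. No evidence is available that bears on this result.

From the compounds shown here alone, whether a hydroxy group, an amine, a carboxylic acid or a longer chain such as ethoxy on this same carbon would also stay within the scatter of compound 2 remains open. Also open, going by these compounds, is whether methoxy on the other carbons of this ring would behave in the same way.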